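The source may hold more compounds than are shown below. What is called first, only, known or untested is meant among the compounds shown, and "the series" means these compounds.

Compound 1 `CCc1c(F)c(N)c2c(=O)cc(-c3ccc(N)c(F)c3)oc2c1F`: in a functional assay on HeLa cells (Homo sapiens) for cytotoxicity, read by neutral red uptake, with a stated time of 3 days (on this read-out lower numbers stand for stronger inhibition and higher numbers for weaker inhibition), compound 1 gives > 100000 nM, which is a limit of the assay, not a number.
Compound 2 `Nc1ccc(-c2cc(=O)c3c(N)c(F)c(C(=O)O)c(F)c3o2)cc1F`: in this assay compound 2 gives > 100000 nM, again a limit.
Compound 3 `CCC(=O)OCc1c(F)c(N)c2c(=O)cc(-c3ccc(N)c(F)c3)oc2c1F`: in this assay compound 3 gives 69000 nM.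

On these data alone, compound 1 stands only at the limit of > 100000 nM in this assay, at which 2 of the 3 values shown sit, so its true number is unknown. Compound 4 `CN(C)CCC(=O)OCc1c(F)c(N)c2c(=O)cc(-c3ccc(N)c(F)c3)oc2c1F` differs from it by ((2-(dimethylamino)ethyl)carbonyl)oxy in place of methyl on a saturated chain carbon bound to an aromatic carbon. Within the data shown here, the one measured step that resembles this change is an at least 1.4-fold lower number from compound 1 to compound 3 (0.16 log units; that floor lies within the scatter), where an ester also replaced the methyl on the saturated chain carbon. That step is small and lies within the scatter. For compound 4 a similarly small downward step, an at least 1.6-fold lower number from compound 1 to compound 4 (0.22 log units; that floor lies within the scatter), is therefore expected in this assay, with a real chance that only a limit is returned. Compound 4 is estimated at 60000 nM, between 20000 nM and 150000 nM.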

Compound 4, half-maximal inhibitory concentration: 11000 nM
Beside the measured number, compound 4's estimate is 5.5-fold (0.74 log units) above it; the measured number lies below the stated range.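

Dimethylamino in place of hydrogen on the ester chain gives a 6.3-fold lower number from compound 3 to compound 4 (0.80 log units; beyond the scatter) in this assay, so at this position the end of the ester chain matters, which the plain ester in compound 3 could not show. Against the earlier compounds, the change reads as an at least 9.0-fold lower number from compound 1 to compound 4 (0.95 log units; beyond the scatter) and an at least 9.0-fold lower number from compound 2 to compound 4 (0.95 log units; beyond the scatter). Those two steps are only floors, because compound 1 and compound 2 each stand at a limit: the limit of > 100000 nM in this assay, at which 2 of the 4 values shown sit.

The compounds shown leave open whether a primary amine, a carboxylic acid or a longer chain at the end of the ester would lower the number as far.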